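A few compounds are considered here, and "the series" means these few. Any claim that something is new, unique, unknown or untested is made for them only; others in the source may bear on it.

Series notes. Compound 1 `O=c1cc(O)c2ccc(OCc3cccc(F)c3)cc2o1` gives 0% in an assay on isolated protein (strain Sprague-Dawley) for inhibition of Amine oxidase [flavin-containing] A (Rattus norvegicus), read by spectrophotometry, with a stated time of 5 min, tested at 10 uM; a lower number here means less inhibition, a higher number more inhibition at the concentration tested (going by the name of the read-out). Going by the values given here, compound 2 `CCOc1cc(=O)oc2cc(OCc3cccc(F)c3)ccc12` gives 25% in this assay, the higher of the two numbers so far; the single step between them, a number 25 percentage points higher from compound 1 to compound 2 (beyond the scatter), is the only measured step in the set.

Compound 3 `CCCOc1cc(=O)oc2cc(OCc3cccc(F)c3)ccc12` is not yet measured. Its change from compound 2 is methyl in place of hydrogen on a saturated chain carbon, two bonds along the chain from an oxygen on an aromatic ring. Among the compounds with values here, the only step that bears on it is a number 25 percentage points higher from compound 1 to compound 2 (beyond the scatter), which built the same chain up from nothing to ethyl; the new change takes that chain one carbon further, from ethoxy to propoxy, and nothing measured tells whether a second extension adds as much. A smaller movement than the first is therefore expected, in the same upward direction, possibly not beyond the scatter, as a number 7 percentage points higher from compound 2 to compound 3 (within the scatter). For compound 3 in this assay the estimate is 32%, with a range from 10% to 55%.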

Compound 3, a percentage reported as inhibition, at one concentration (the size of the read-out at that concentration, not a potency): 12%
Beside the measured number, compound 3's estimate is 20 percentage points above it; measured number inside the range.
By their numbers in this assay, from the lowest: compound 1; then compound 3; then compound 2.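

In this assay, taking the ethoxy chain to propoxy gives a number 13 percentage points lower from compound 2 to compound 3 (beyond the scatter), so the earlier gain on this oxygen does not continue with the added methyl. Compared with hydrogen on that oxygen, propyl still gives a number 12 percentage points higher from compound 1 to compound 3 (beyond the scatter), which leaves ethyl with the highest number of the three substituents and shows that the response across compound 1, compound 2 and compound 3 does not climb steadily with chain length. No measurement at hand bears on the reason for this reversal.

Going by these compounds, it remains open whether a butoxy or longer chain lowers the number further, and where a methoxy or a branched isopropoxy would fall in this order. Also open, on these data alone, is how an amine or a carboxylic acid carried on this chain would compare with the plain ethoxy and propoxy chains.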